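This account rests on a few compounds, and the source may have more. Where it says the series, first, only, none or still open, it means among the compounds named here.

In a functional assay on HepG2 cells (Homo sapiens) for antiproliferative activity, read by sulforhodamine B assay, with a stated time of 48 h (on this read-out higher numbers stand for weaker inhibition and lower numbers for stronger inhibition), compound 1 (`COc1ccc(C=C(C(=O)/C=C/c2cccc(OC)c2OC)C(=O)/C=C/c2cccc(OC)c2OC)cc1O`) gives 270 nM and compound 2 (`COc1ccc(OC)c(/C=C/C(=O)C(=Cc2ccc(O)c(OC)c2)C(=O)/C=C/c2cc(OC)ccc2OC)c1`) gives 340 nM so the two values lie within the scatter of each other. Compound 3 (`COc1ccc(OC)c(/C=C/C(=O)C(=Cc2ccc(OC)c(O)c2)C(=O)/C=C/c2cc(OC)ccc2OC)c1`) has not yet been measured. Its difference from compound 2 is 3-hydroxy-4-methoxyphenyl in place of 4-hydroxy-3-methoxyphenyl on a double-bonded chain carbon bound to a double-bonded chain carbon on a double-bonded chain carbon bound to a double-bonded chain carbon, and the two have the same atoms, joined differently. Going by the values given here, no measured pair shows this change alone. Compound 1 carries 3-hydroxy-4-methoxyphenyl at that place and gives 270 nM in this assay although it also differs from compound 3 elsewhere, so no step beyond the scatter is expected in either direction. The estimate amounts to an expected 1.1-fold lower number from compound 2 to compound 3 (0.05 log units; within the scatter) within the scatter. Compound 3 is expected at 300 nM (estimated range 130 nM to 700 nM).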

Compound 3, half-maximal inhibitory concentration: 470 nM
Compound 3: the middle estimate sits 1.6-fold (0.19 log units) below what was measured, and the stated range covers the measured number.
By their numbers in this assay, from the lowest: compounds 1, 2 and 3 (each within the scatter of the next).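

In this assay, going by these compounds alone, the exchange of 4-hydroxy-3-methoxyphenyl for 3-hydroxy-4-methoxyphenyl on a double-bonded chain carbon bound to a double-bonded chain carbon gives a 1.4-fold higher number from compound 2 to compound 3 (0.14 log units; within the scatter) and is the first pair to show this change alone. At this place, with the rest of the molecule held constant, the two phenyl groups therefore cannot be told apart on this read-out. No measurement shown here bears on the reason for this result.

Going by these compounds, what remains open is whether any group at this place would move the number beyond the scatter, such as an amine or a carboxylic acid in place of the hydroxy group, or an ethoxy group in place of the methoxy group. On these data alone, it is also open whether the same exchange would stay within the scatter on a core with different outer aryl groups.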